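The source may report more compounds than this note shows. Statements on the series, on what has been measured and on what is new or still open speak of the compounds shown alone.

In an ADME assay on the whole organism (blood, Mus musculus, strain C57BL/6) for pharmacokinetics, read by HPLC, with a stated time of 4 h, at a dose of 2 mg/kg by the intraperitoneal route (a lower number here means less compound in the circulation, a higher number more compound in the circulation at the dose given), compound 1 `CCS(=O)(=O)c1c(Cl)ccc(NC(=O)Nc2cccc(Cl)c2Cl)c1O` gives 256 ng.h/mL, while compound 2 `CC(C)N1CCN(S(=O)(=O)c2c(Cl)ccc(NC(=O)Nc3cccc(F)c3Cl)c2O)CC1` gives 52.9 ng.h/mL, the lower of the two numbers and beyond the scatter from compound 1. Compound 3 `CCN1CCN(S(=O)(=O)c2c(Cl)ccc(NC(=O)Nc3cccc(F)c3Cl)c2O)CC1` has not yet been measured. It differs from compound 2 in one place: hydrogen in place of methyl on a saturated chain carbon bound to an amine nitrogen in a ring and a saturated chain carbon. Going by the values given here, no step between measured compounds covers this change, so its size is uncertain. The expected step of a 1.2-fold higher number from compound 2 to compound 3 (0.09 log units; within the scatter) is small, upward if anything, and may well not clear the scatter. Compound 3 is therefore estimated at 65 ng.h/mL, within 30 ng.h/mL to 140 ng.h/mL.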

Compound 3, area under the concentration-time curve: 189 ng.h/mL
Compound 3: middle estimate off by 2.9-fold (0.46 log units), on the low side; measured number outside the range, above it.
By their numbers in this assay, from the lowest: compound 2; then compounds 3 and 1 (each within the scatter of the next).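

Within this assay the change from 4-isopropylpiperazin-1-yl to 4-ethylpiperazin-1-yl gives a 3.6-fold higher number from compound 2 to compound 3 (0.55 log units; beyond the scatter) and so clears the scatter. This position is therefore not silent: losing one methyl, with no change in hydrogen-bond donors, hydrogen-bond acceptors or net charge, is enough to shift the exposure read-out. On these data alone, a single step sets no trend, so it remains open whether a methyl or a bare hydrogen on the ring amine nitrogen, or a longer chain there, would follow the same direction. Nothing measured here accounts for the size of this step.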